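Cyclobutanol to methoxycyclohexyl at the ring amine

The source may hold more compounds than are shown below. What is called first, only, known or untested is meant among the compounds shown, and "the series" means these compounds.

Measured compounds:
compound 1 `N#Cc1cnc(NCc2cnccc2C(F)(F)F)cc1N[C@H]1C[C@@H](O)C1`: > 10000 nM
compound 2 `N#Cc1cnc(NCc2cnccc2C(F)(F)F)cc1N[C@H]1C[C@H](O)C1`: > 10000 nM
compound 3 `CO[C@H]1CC[C@@H](Nc2cc(NCc3cnccc3C(F)(F)F)ncc2C#N)CC1`: 5000 nM

In an assay on isolated protein for inhibition of protein kinase C delta type (Homo sapiens), read by TR-FRET, with a stated time of 2 h (on this read-out lower numbers stand for stronger inhibition and higher numbers for weaker inhibition), compound 1 gives only a limit of the assay, > 10000 nM. Compound 2 likewise sits at a limit, > 10000 nM. Compound 3 gives a number, 5000 nM. The step that the two limits leave unreadable from compound 1 to compound 2 cannot be read, given the limit of > 10000 nM in this assay, at which 2 of the 3 values shown sit, and (the fact that compounds 1 and 2 differ only in the configuration as drawn). The steps of an at least 2.0-fold lower number from compound 1 to compound 3 (0.30 log units; that floor lies within the scatter) and an at least 2.0-fold lower number from compound 2 to compound 3 (0.30 log units; that floor lies within the scatter) both run downward, with floors that lie within the scatter.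

Compound 4 `CO[C@H]1CC[C@H](Nc2cc(NCc3cnccc3C(F)(F)F)ncc2C#N)CC1` carries the same change as compound 3 relative to compound 1: 4-methoxycyclohexyl in place of 3-hydroxycyclobutyl on a nitrogen on an aromatic ring. For the measured compounds named here, compound 4 and compound 3 share atoms and bonds and differ only in configuration as drawn; no step between them has been measured. Going by the values given here, the steps that bear on compound 4 are therefore those to compound 3, which only set a floor. The expected step is an at least 2.0-fold lower number from compound 1 to compound 4 (0.30 log units; that floor lies within the scatter), downward from the limit into readable numbers. Compound 4 is estimated at 5000 nM in this assay, with a range of 1500 nM to 15000 nM.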

Compound 4, half-maximal inhibitory concentration: > 10000 nM
Compound 4: a limit, no number; the forecaster's own chance of this, stated with the estimate: 35%; at least 2.0-fold (0.30 log units) between middle value and limit.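

In this assay compound 4 gives > 10000 nM, a limit of the assay and not a number. The 4-methoxycyclohexyl group on the nitrogen therefore does not by itself give a readable value, since only one of the two drawn configurations does so, and an at least 2.0-fold higher number from compound 3 to compound 4 (0.30 log units; that floor lies within the scatter) stays a floor that does not establish a real difference between these two compounds: the fact that compounds 3 and 4 differ only in the configuration as drawn. The steps from compound 1 and compound 2 to compound 4 cannot be read, with both ends of each step at: the limit of > 10000 nM in this assay, at which 3 of the 4 values shown sit.

Going by these compounds, how far compounds 1, 2 and 4 lie past the limit remains open, as does whether the gap between compound 3 and compound 4 exceeds the scatter. Also open, on these data alone, is how an amine or a carboxylic acid in place of the methoxy group on the cyclohexyl ring would read in either configuration.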